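Thiazole to thiadiazole on the sulfonamide nitrogen

A few compounds are considered here, and "the series" means these few. Any claim that something is new, unique, unknown or untested is made for them only; others in the source may bear on it.

Measured so far:
compound 1, `Cn1nccc1[C@H]1CCC[C@@H]1Oc1cc(F)c(S(=O)(=O)Nc2nccs2)cc1F`: 13000 nM
compound 2, `Cn1nccc1[C@H]1CCC[C@@H]1Oc1ccc(S(=O)(=O)Nc2ccncn2)c(F)c1F`: > 100000 nM

Going by the values given here, in an ADME assay on HEK293-A cells for inhibition of sodium channel protein type 1 subunit alpha/beta-1/beta-2 (Homo sapiens), read by patch clamp (on this read-out higher numbers stand for weaker inhibition and lower numbers for stronger inhibition), compound 1 gives 13000 nM, the only numerical value in the set. Compound 2 reaches only a limit of the assay, (the limit of > 100000 nM in this assay, at which 1 of the 2 values shown sits), and no number is known for it. Among the compounds with values here, no step between two measured compounds is available, so the effect of any single structural change has not been observed directly.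

Compound 3, `Cn1nccc1[C@H]1CCC[C@@H]1Oc1cc(F)c(S(=O)(=O)Nc2ncns2)cc1F`, differs from compound 1 in one place: 1,2,4-thiadiazol-5-yl in place of 1,3-thiazol-2-yl on a sulfonamide nitrogen. The shared core and the two fluorine-bearing aromatic ring are unchanged. Within the data shown here, with no measured step to lean on, the expectation for this assay is a step from compound 1 to compound 3 of modest size, if any, and toward stronger inhibition rather than weaker, but not clearly beyond the usual scatter; the expected step is a 1.6-fold lower number from compound 1 to compound 3 (0.21 log units; within the scatter). For compound 3 the estimate in this assay is 8000 nM, expected within 2500 nM to 30000 nM.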

Compound 3, half-maximal inhibitory concentration in the sodium channel protein type 1 subunit alpha/beta-1/beta-2 assay: 26000 nM
Compound 3: middle estimate off by 3.3-fold (0.51 log units), on the low side; measured number inside the range.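

Going by these compounds alone, in the sodium channel protein type 1 subunit alpha/beta-1/beta-2 assay, 1,2,4-thiadiazol-5-yl in place of 1,3-thiazol-2-yl on the sulfonamide nitrogen gives a 2.0-fold higher number from compound 1 to compound 3 (0.30 log units; within the scatter), the first step that can be read directly, and it does not separate the two compounds. In a physicochemical assay for lipophilicity, read by LC-MS, in phosphate buffer, measured as octanol-water partition, with a stated time of 30 min, at pH 7.4 (a higher number here means a more lipophilic compound, a lower number a more polar compound), compound 1 gives 2.1 and compound 3 gives 0.6. Read together, this position takes a large change in the physicochemical assay, a number 1.50 log units lower from compound 1 to compound 3 (beyond the scatter), with no step beyond the scatter in the sodium channel protein type 1 subunit alpha/beta-1/beta-2 assay.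

Within the data shown here, in the sodium channel protein type 1 subunit alpha/beta-1/beta-2 assay compound 2 gives only a limit of the assay, > 100000 nM, and no step to it can be read. On these data alone, what a pyridine or an oxazole on the sulfonamide nitrogen would give in either read-out stays open, as does the effect of moving a fluorine on the aromatic ring with the thiazole or thiadiazole held constant.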